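The compounds below may be only part of what the source reports. "The series", "measured", "known", "first", "only" and "open" are said of these compounds alone.

Compound 3 `CC(C)(C)N(NC(=O)c1cccc(F)c1)C(=O)c1ccccc1Cl` and compound 4 `CC(C)(C)N(NC(=O)c1cccc(Cl)c1)C(=O)c1ccccc1Cl` share one core, and compound 4 differs from compound 3 only by chloro in place of fluoro on an aromatic carbon. A change of the same kind separates compound 1 `CC(C)(C)N(NC(=O)c1ccccc1F)C(=O)c1ccccc1Cl` from compound 2 `CC(C)(C)N(NC(=O)c1ccccc1Cl)C(=O)c1ccccc1Cl`, counted as chloro in place of fluoro on an aromatic carbon. In an assay on cells for agonist activity at ecdysone receptor (Bombyx mori), read by a luciferase reporter, with a stated time of 24 h (a lower number here means that less compound is needed, a higher number that more compound is needed for the effect), compound 1 gives 51.3 nM, while compound 2 gives 331 nM, so that a 6.5-fold higher number from compound 1 to compound 2 (0.81 log units; beyond the scatter). The core of compound 3 differs from the core of compound 1 by 3-fluorophenyl in place of 2-fluorophenyl on a carbonyl carbon; in this assay compound 3 gives 69.2 nM, and a 1.3-fold higher number from compound 1 to compound 3 (0.13 log units; within the scatter), while a 4.8-fold lower number from compound 2 to compound 3 (0.68 log units; beyond the scatter).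

The two places are not identical. In the step from compound 1 to compound 2 the change sits ortho to a large group; in the step from compound 3 to compound 4 it sits meta to a large group. It is therefore the same kind of change, not the same change, and the earlier step can guide but not fix what follows. Compound 4 is expected to show a 2.9-fold higher number from compound 3 to compound 4 (0.46 log units; beyond the scatter), a step set beside the earlier one and somewhat smaller, because compound 2 gives 331 nM after the same kind of change from compound 1, whereas the move of fluorine between the two places leaves compound 3 close to compound 1. On that basis compound 4 is estimated at 200 nM in this assay, with a range from 80 nM to 600 nM.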

Compound 4, half-maximal effective concentration: 155 nM
Beside the measured number, compound 4's estimate is 1.3-fold (0.11 log units) above it; the range from low to high includes it.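

In this assay chloro in place of fluoro gives a higher number on both cores shown, so the direction of the change carries from the core of compound 1 to the core of compound 3 (a 2.2-fold higher number from compound 3 to compound 4 (0.35 log units; beyond the scatter)). Compound 4 also stands apart from its other two neighbours: 3-chlorophenyl in place of 2-chlorophenyl gives a lower number (a 2.1-fold lower number from compound 2 to compound 4 (0.33 log units; beyond the scatter)), and 3-chlorophenyl in place of 2-fluorophenyl gives a higher one (a 3.0-fold higher number from compound 1 to compound 4 (0.48 log units; beyond the scatter)). What these compounds do not show is a size of step that can be carried unchanged from one core to the other, and they give no reason why the size differs: the same change on two cores in this assay, a 6.5-fold higher number (0.81 log units; beyond the scatter) from compound 1 to compound 2 and a 2.2-fold higher number (0.35 log units; beyond the scatter) from compound 3 to compound 4, 2.9-fold (0.46 log units) apart, beyond the scatter of two such steps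

Among the compounds shown here, with only two pairs on two cores, it stays open whether the direction would hold on any further core, or whether it would hold for bromo or methyl on the same aromatic carbon. The compounds shown also leave open how a methoxy group or a nitrile would compare with chloro and fluoro in this assay, and whether the step from fluoro to chloro would keep its direction if the 2-chlorophenyl group on the other carbonyl carbon were replaced.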